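Methoxyphenyl Variant in an MT4 Cell Cytotoxicity Series

The source may report more compounds than this note shows. Statements on the series, on what has been measured and on what is new or still open speak of the compounds shown alone.

Three compounds have been measured in an ADME assay on MT4 cells (Homo sapiens) for cytotoxicity, read by MTT assay, with a stated time of 4 days; on this read-out lower numbers stand for higher toxicity in this test and higher numbers for lower toxicity in this test:

Compound 1, `Cc1cc(-c2cccc(Cl)c2)cc(C)c1Nc1ccnc(Nc2ccc(C#N)cc2)n1`: 2160 nM
Compound 2, `Cc1cc(-c2cc(Cl)cc(Cl)c2)cc(C)c1Nc1ccnc(Nc2ccc(C#N)cc2)n1`: 4290 nM
Compound 3, `Cc1ccccc1-c1cc(C)c(Nc2ccnc(Nc3ccc(C#N)cc3)n2)c(C)c1`: 3820 nM

Compound 3 lies within the usual scatter of both other compounds in this assay: the step of a 1.8-fold higher number from compound 1 to compound 3 (0.25 log units; within the scatter) and the step of a 1.1-fold lower number from compound 2 to compound 3 (0.05 log units; within the scatter) are both small, and the step of a 2.0-fold higher number from compound 1 to compound 2 (0.30 log units; within the scatter) between the two chlorinated analogues is small as well. Across these three compounds the aryl group carried on the shared core has been varied without any number moving beyond the scatter.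

Compound 4, `COc1cccc(-c2cc(C)c(Nc3ccnc(Nc4ccc(C#N)cc4)n3)c(C)c2)c1`, is not yet measured. It differs from compound 3 in one place: 3-methoxyphenyl in place of 2-methylphenyl on an aromatic carbon. For the measured compounds named here, the steps that bear on this change are the two in which the aryl group was exchanged, from compound 1 to compound 3 and from compound 2 to compound 3, and both stayed within the scatter. Going by the values given here, no measured step involves a methoxy group, so nothing points in a particular direction. The expected step of a 1.1-fold lower number from compound 3 to compound 4 (0.04 log units; within the scatter) is therefore none beyond the scatter. Compound 4 is estimated at 3500 nM in this assay, with a range from 1500 nM to 8000 nM.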

Compound 4, half-maximal cytotoxic concentration: 2990 nM
Estimate against measurement, compound 4: 1.2-fold (0.07 log units) above; low and high end bracket the measured number.
By their numbers in this assay, from the lowest: compounds 1, 4, 3 and 2 (each within the scatter of the next).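

In this assay the change to 3-methoxyphenyl at this position, para to a large group, gives a 1.3-fold lower number from compound 3 to compound 4 (0.11 log units; within the scatter) and, against the dichlorinated analogue, a 1.4-fold lower number from compound 2 to compound 4 (0.16 log units; within the scatter) while all of these steps stay within the scatter. For the compounds shown here, the exchange of chloro for methoxy at the same place on the aryl ring gives a 1.4-fold higher number from compound 1 to compound 4 (0.14 log units; within the scatter) and likewise stays within the scatter, so this is the first reading in which an oxygen-bearing group stands on the aryl ring, and the number does not separate from those of the chloro and methyl compounds. The entering group also carries a hydrogen-bond acceptor, which 2-methylphenyl lacks, and even this difference in the counted features leaves compound 4 within the scatter of compound 3, so all four compounds now sit together in this test.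

Still open, on these data alone, is whether an amine or a carboxylic acid on this aryl ring, or a longer chain in its place, would move the number beyond the scatter. Nothing measured here gives a reason why these four numbers stay so close.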